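Ester side chain swap on a sesquiterpene lactone core

The source may hold more compounds than are shown below. What is called first, only, known or untested is meant among the compounds shown, and "the series" means these compounds.

Compound 1 `C=C1C(=O)O[C@H]2CC3=C[C@H](C/C(C)=C/[C@@H](OC(=O)/C=C/c4ccc(N(C)C)cc4)[C@H]12)OC3=O` gives 1300 nM in a functional assay on NCI-H460 cells (Homo sapiens) for cytotoxicity, read by MTT assay, with a stated time of 48 h; on this read-out higher numbers stand for weaker inhibition and lower numbers for stronger inhibition.
Compound 2 `C=C1C(=O)O[C@H]2CC3=C[C@H](C/C(C)=C/[C@@H](OC(=O)CC(C)C)[C@H]12)OC3=O` gives 3800 nM in this assay.
Compound 3 `C=C1C(=O)O[C@H]2CC3=C[C@H](C/C(C)=C/[C@@H](OC(=O)/C=C/c4cccs4)[C@H]12)OC3=O` gives 2900 nM in this assay.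

Three compounds share one core and differ only in the ester group hung on it. Compound 1 stands lowest of the three numbers, meaning the strongest inhibition in this assay; the step to its nearest neighbour is a 2.2-fold higher number from compound 1 to compound 3 (0.35 log units; beyond the scatter), and the step to the furthest is a 2.9-fold higher number from compound 1 to compound 2 (0.47 log units; beyond the scatter). Between the other two the difference is a 1.3-fold lower number from compound 2 to compound 3 (0.12 log units; within the scatter).

Compound 4 `C=C1C(=O)O[C@H]2CC3=C[C@H](C/C(C)=C/[C@@H](OC(=O)/C=C/c4ccncc4)[C@H]12)OC3=O` is not yet measured. It differs from compound 1 in one place: pyridin-4-yl in place of 4-(dimethylamino)phenyl on a double-bonded chain carbon bound to a double-bonded chain carbon.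

The step that bears most directly on this change is the one in which the same 4-(dimethylamino)phenyl group was exchanged for another aromatic ring, giving a 2.2-fold higher number from compound 1 to compound 3 (0.35 log units; beyond the scatter), a modest move towards weaker inhibition. The other aromatic-to-alkyl change, a 2.9-fold higher number from compound 1 to compound 2 (0.47 log units; beyond the scatter), pointed the same way and was a little larger. A pyridin-4-yl ring is another aromatic replacement of the same kind, so a modest step in the same direction is expected, a 2.0-fold higher number from compound 1 to compound 4 (0.30 log units; within the scatter).

Compound 4 is therefore estimated at 2600 nM, with a likely range from 1200 nM to 5500 nM.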

Compound 4, half-maximal inhibitory concentration: 2100 nM
For compound 4 the middle estimate is 1.2-fold (0.09 log units) above the measured one; measured number inside the range.
By their numbers in this assay, from the lowest: compounds 1, 4, 3 and 2 (each within the scatter of the next, the first and the last beyond it).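

In this assay, replacing 4-(dimethylamino)phenyl with pyridin-4-yl, six heavy atoms in place of nine, gives a 1.6-fold higher number from compound 1 to compound 4 (0.21 log units; within the scatter), so this exchange at the double-bonded chain carbon cannot be told apart from no change, whereas the exchange for thiophen-2-yl gave a step printed as beyond the scatter. Compound 4 also cannot be separated from either of the other two compounds, with a 1.4-fold lower number from compound 3 to compound 4 (0.14 log units; within the scatter) and a 1.8-fold lower number from compound 2 to compound 4 (0.26 log units; within the scatter), so it sits within the scatter of compound 1 and of compound 2 even though those two are separated from each other. No measurement is available to explain any of these steps.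

The compounds shown leave open what the dimethylamino group contributes by itself, as the step from compound 1 to compound 4 removes that group and places a nitrogen in the ring at the same time. A plain phenyl ring on the same ethenyl chain would separate those two changes, and a 4-methoxyphenyl ring would show whether a different group can stand in the dimethylamino group's place.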